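The source may hold more compounds than are shown below. What is called first, only, known or untested is meant among the compounds shown, and "the series" means these compounds.

Working notes on the series. Compound 2 `O=C(Nn1c(-c2cccc([N+](=O)[O-])c2)nc2c(-c3ccc(F)cc3)n[nH]c2c1=O)c1ccccc1` is the reference point. In a functional assay on SK-MEL-2 cells (Homo sapiens) for cytotoxicity, read by sulforhodamine B assay, with a stated time of 2 days, tested at 100 uM (a higher number here means more inhibition at the concentration tested (going by the name of the read-out), a lower number less inhibition), compound 2 gives 88.5%, the highest of the two numbers recorded so far. Going by the values given here, compound 1 `O=C(Nn1c(-c2cccc([N+](=O)[O-])c2)nc2c(CCc3ccccc3)n[nH]c2c1=O)c1cccnc1` differs from compound 2 in two places, and in this assay compound 1 gives 28.5%, a gap to compound 2 well beyond the scatter; with two changes at once, no single step between them can be read off.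

Compound 3 `O=C(Nn1c(-c2cccc([N+](=O)[O-])c2)nc2c(CCc3ccccc3)n[nH]c2c1=O)c1ccccc1` is the next to go into this assay. Against compound 2 the change is phenethyl in place of 4-fluorophenyl on an aromatic carbon. The same phenethyl group is carried by compound 3 and by compound 1, and in this assay compound 1 gives 28.5%, though compound 1 also differs in its amide part, so the phenethyl effect is not isolated on the data at hand. The expected step in this assay is a number 46.5 percentage points lower from compound 2 to compound 3 (beyond the scatter), a fall beyond the scatter. Compound 3 is estimated at 42% in this assay, with a range from 15% to 75%.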

Compound 3, a percentage reported as inhibition, at one concentration (the size of the read-out at that concentration, not a potency): 92%
Estimate against measurement, compound 3: 50 percentage points below; the measured number lies above the stated range.
By their numbers in this assay, from the lowest: compound 1; then compounds 2 and 3 (each within the scatter of the next).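

Phenethyl in place of 4-fluorophenyl on this aromatic carbon gives a number 3.5 percentage points higher from compound 2 to compound 3 (within the scatter) in this assay, so with the phenyl on the carbonyl carbon held fixed, the two groups cannot be told apart at this position. With phenethyl held fixed, phenyl in place of pyridin-3-yl on a carbonyl carbon gives a number 63.5 percentage points higher from compound 1 to compound 3 (beyond the scatter) in this assay, which places the large gap between compound 1 and compound 3 at the amide part and not at the phenethyl group. No measurement at hand gives a reason for either step.

Going by these compounds, it remains open how this aromatic carbon responds to an amine, a carboxylic acid or a chain longer than phenethyl. Also open, on these data alone, is whether pyridin-3-yl on the carbonyl carbon has a step of similar size when 4-fluorophenyl stands on the aromatic carbon.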